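A few compounds are considered here, and "the series" means these few. Any claim that something is new, unique, unknown or untested is made for them only; others in the source may bear on it.

Measured in a functional assay on KG-1 cells (Homo sapiens) for cytotoxicity, read by luminescence and CellTiter-Glo, with a stated time of 3 days; a higher number here means a weaker inhibitor, a lower number a stronger inhibitor:
- compound 1 `N#Cc1ccc(NC(=O)c2cc(Cl)ccc2O)c(Cl)c1`: 860 nM
- compound 2 `COc1ccc(O)c(C(=O)Nc2ccc(C#N)cc2)c1`: > 10000 nM, a limit of the assay
- compound 3 `N#Cc1ccc(NC(=O)c2cc(F)ccc2O)cc1`: 2670 nM

Of the two numeric values, the higher belongs to compound 3 at 2670 nM. Compound 1 at 860 nM lies lower, by more than the scatter.

The next compound is compound 4 `N#Cc1ccc(NC(=O)c2cc(Cl)ccc2O)cc1`, with chloro in place of fluoro on an aromatic carbon.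

One measured step changes this same place: an at least 3.7-fold lower number from compound 2 to compound 3 (0.57 log units; beyond the scatter). It starts from a limit, so its true size is open, and it shows a replacement of methoxy rather than of fluoro. Compound 1 at 860 nM also carries the entering chloro, but it is not a single-change neighbour of compound 3, so it is only a weak pointer towards a lower number.

A small lowering in this assay is expected, possibly not beyond the scatter: the estimated step is a 1.8-fold lower number from compound 3 to compound 4 (0.25 log units; within the scatter).

For compound 4 the estimated value is 1500 nM, with an expected range of 600 nM to 4000 nM.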

Compound 4, half-maximal inhibitory concentration: 1860 nM
Estimate against measurement, compound 4: 1.2-fold (0.09 log units) below; low and high end bracket the measured number.
By their numbers in this assay, from the lowest: compound 1; then compounds 4 and 3 (each within the scatter of the next). At a limit, above all of these: compound 2.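

In this assay, exchanging one halogen for the other on the aromatic carbon para to a hydroxy group gives a 1.4-fold lower number from compound 3 to compound 4 (0.16 log units; within the scatter), so this position does not separate fluoro from chloro. Chloro in place of methoxy at the same position gives an at least 5.3-fold lower number from compound 2 to compound 4 (0.73 log units; beyond the scatter), a step that starts from a limit and so fixes only a minimum size: the limit of > 10000 nM in this assay, at which 1 of the 4 values shown sits.

Hydrogen in place of the second chloro of compound 1 gives a 2.2-fold higher number from compound 1 to compound 4 (0.34 log units; beyond the scatter), so a change at that other place moves the number beyond the scatter, which the halogen exchange does not do.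

The compounds shown leave open how hydrogen, an amine or a carboxylic acid para to the hydroxy group would compare with fluoro and chloro. Also open, as far as these compounds go, is whether the second chloro would have a similar effect with fluoro in place of the first.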